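This account rests on a few compounds, and the source may have more. Where it says the series, first, only, none or still open, it means among the compounds named here.

For the measured compounds named here, compound 3, `CC(C)(C)c1ccc(-c2ccc3c(NCCCNCc4ccco4)ccnc3c2)cc1`, stands at the top of the three numbers measured so far in a physicochemical assay for solubility, with a stated time of 18 h, at pH 7.4; a higher number here means a more soluble compound, a lower number a less soluble compound: compound 3 gives 32000 nM. The two other measured compounds sit well below it. Compound 1, `CC(C)Cc1ccc2c(NCCCNCc3ccco3)ccnc2c1`, gives 4200 nM, and compound 2, `Fc1ccc(Cc2ccc3c(NCCCNCc4ccco4)ccnc3c2)c(Cl)c1`, gives 4200 nM. The step of a 7.6-fold higher number from compound 1 to compound 3 (0.88 log units; beyond the scatter) and the step of a 7.6-fold higher number from compound 2 to compound 3 (0.88 log units; beyond the scatter) both separate compound 3 from its neighbours, while the step of no change at the digits printed from compound 1 to compound 2 (within the scatter) shows that an exchange between isobutyl and 2-chloro-4-fluorobenzyl at the same position left the number where it was.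

Compound 4, `c1coc(CNCCCNc2ccnc3cc(CC4CCCCC4)ccc23)c1`, has not yet been measured in this assay. It differs from compound 3 in one place: cyclohexylmethyl in place of 4-(tert-butyl)phenyl on an aromatic carbon. The two steps that bear on this change are those leading into compound 3, since both replace a saturated-chain substituent on that aromatic carbon by 4-(tert-butyl)phenyl and both raised the number by the same modest amount. Compound 4 returns to a saturated-chain substituent, cyclohexylmethyl, resembling isobutyl in compound 1 more than the aryl group in compound 3. The step of a 6.4-fold lower number from compound 3 to compound 4 (0.81 log units; beyond the scatter) is therefore expected to run downward, roughly undoing the earlier rise. For compound 4 a value of about 5000 nM is estimated, within a range from 2000 nM to 13000 nM.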

Compound 4, solubility: 4200 nM
The estimate for compound 4 lay 1.2-fold (0.08 log units) above the measured number, and the stated range covers the measured number.
By their numbers in this assay, from the lowest: compounds 1, 2 and 4 (each within the scatter of the next); then compound 3.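

In this assay the return to a chain-linked group brings a 7.6-fold lower number from compound 3 to compound 4 (0.88 log units; beyond the scatter) and lands on the level of the other two compounds, with no change at the digits printed from compound 2 to compound 4 (within the scatter) and no change at the digits printed from compound 1 to compound 4 (within the scatter) in the same reading. What compound 4 adds is a third group bound through a saturated chain carbon at this position: cyclohexylmethyl joins isobutyl and 2-chloro-4-fluorobenzyl, and the three cannot be told apart here even though their ends differ, a branched chain in compound 1, an aromatic ring in compound 2 and a non-aromatic ring in compound 4. Among the four compounds, only compound 3, with its 4-(tert-butyl)phenyl ring bound directly to the aromatic carbon, stands apart, and no compound goes against this pattern.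

The compounds shown leave open whether the higher number of compound 3 goes with the directly bound ring or with the tert-butyl on it, which a plain phenyl would help to separate, and how a group such as an amine or a carboxylic acid would read on this aromatic carbon. Nothing at hand gives a reason for any of these steps.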